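Aryl diazenyl alanine amides: lipophilicity at the aromatic substituent

A few compounds are considered here, and "the series" means these few. Any claim that something is new, unique, unknown or untested is made for them only; others in the source may bear on it.

Measured compounds:
compound 1, `CC(=O)N[C@@H](C)C(=O)N(C)/N=N/c1ccc(C(N)=O)cc1`, 0.69
compound 2, `CC(=O)N[C@@H](C)C(=O)N(C)/N=N/c1ccc(C#N)cc1`, 1.41

The two measured compounds share the acetylalanyl methyl-triazene core and differ only in the group on the aromatic ring. In a physicochemical assay for lipophilicity, read by HPLC, in phosphate buffer, measured as octanol-water partition, at pH 7.4 (a lower number here means a more polar compound, a higher number a more lipophilic compound), compound 1 gives 0.69 and compound 2 gives 1.41. Going by the values given here, compound 2 therefore stands highest of the two, with compound 1 as its only neighbour, and the step of a number 0.72 log units higher from compound 1 to compound 2 (beyond the scatter) lies beyond the scatter.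

Compound 3, `CC(=O)N[C@@H](C)C(=O)N(C)/N=N/c1ccc(C)cc1`, has not yet been measured in this assay. It differs from compound 2 in one place: methyl in place of cyano on an aromatic carbon. Among the compounds with values here, the only measured step that bears on this position is the exchange of carbamoyl for cyano, a number 0.72 log units higher from compound 1 to compound 2 (beyond the scatter), which removed a hydrogen-bond donor pair and shifted the partition coefficient upward by a modest amount. The change to compound 3 removes the remaining hydrogen-bond acceptor at that position and replaces it with a group carrying no donors or acceptors, so a further upward step is expected, probably at least as large as the one already seen. For compound 3 the expected value in this assay is 2.2, with a range from 1.7 to 2.7. This corresponds to an estimated step of a number 0.79 log units higher from compound 2 to compound 3 (beyond the scatter).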

Compound 3, partition coefficient: 2.45
Beside the measured number, compound 3's estimate is 0.25 log units below it; measured number inside the range.
By their numbers in this assay, from the lowest: compound 1; then compound 2; then compound 3.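

In this assay, the exchange of nitrile for methyl on this aromatic carbon gives a number 1.04 log units higher from compound 2 to compound 3 (beyond the scatter), a step printed as large, whereas the earlier exchange at the same place, a number 0.72 log units higher from compound 1 to compound 2 (beyond the scatter), was modest. Across the three groups the position spans a number 1.76 log units higher from compound 1 to compound 3 (beyond the scatter) with the shared core unchanged, so the choice of group at this one place moves the partition coefficient widely, and the series runs in order from carbamoyl through nitrile to methyl. The entering methyl carries no hydrogen-bond donors or acceptors, but no measurement on hand accounts for the size of either step.

The compounds shown leave open how an ethyl group or a longer alkyl chain at this place would compare with methyl, and where an amine or a carboxylic acid would fall in the order. From the compounds shown here alone, they also keep the rest of the shared core fixed, so whether steps of this size carry over to a core with a different acyl group on the alanine remains unknown.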